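This account rests on a few compounds, and the source may have more. Where it says the series, first, only, none or still open, it means among the compounds named here.

Of the compounds shown here, three on the shared core have values so far in a functional assay on SW1573 cells (Homo sapiens) for antiproliferative activity, read by sulforhodamine B assay, with a stated time of 48 h (on this read-out lower numbers stand for stronger inhibition of growth and higher numbers for weaker inhibition of growth), and differ only in the side chain. Compound 1 `CCCCCCC(C#CC(=O)OC)O/C=C/C(=O)OC` gives 3300 nM as its reading, compound 2 `CCCC(C#CC(=O)OC)O/C=C/C(=O)OC` gives 320 nM on the same read-out, and compound 3 `COC(=O)C#CC(CCc1ccccc1)O/C=C/C(=O)OC` gives 2600 nM in this set. Compound 3 belongs with the higher pair of numbers: a 1.3-fold lower number from compound 1 to compound 3 (0.10 log units; within the scatter) stays within the scatter, while an 8.1-fold higher number from compound 2 to compound 3 (0.91 log units; beyond the scatter) lies beyond it.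

Going to compound 4 `COC(=O)C#CC(C)O/C=C/C(=O)OC` takes the benzyl off (hydrogen in place of benzyl on a saturated chain carbon, two bonds along the chain from an oxygen on an unsaturated carbon and a triple-bonded carbon), leaving hydrogen in place of benzyl on a saturated chain carbon, two bonds along the chain from an oxygen on an unsaturated carbon and a triple-bonded carbon.

For the measured compounds named here, two measured steps bear on this change. The first, a 10-fold lower number from compound 1 to compound 2 (1.01 log units; beyond the scatter) with hydrogen in place of propyl, and the second, an 8.1-fold higher number from compound 2 to compound 3 (0.91 log units; beyond the scatter) with phenyl in place of methyl, both give the lower number to the compound with the smaller side chain. From the compounds shown here alone, no side chain as short as that of compound 4 has been measured, so whether this continues remains open. The expected change is a 6.5-fold lower number from compound 3 to compound 4 (0.81 log units; beyond the scatter) in this assay as a step beyond the scatter. For compound 4 the estimate is 400 nM with an expected range of 120 nM to 1300 nM on this read-out.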

Compound 4, concentration for 50% growth inhibition: 1700 nM
Compound 4: the middle estimate sits 4.3-fold (0.63 log units) below what was measured, outside the stated range (above it).
By their numbers in this assay, from the lowest: compound 2; then compounds 4, 3 and 1 (each within the scatter of the next).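

Taking off the benzyl, on a saturated chain carbon, two bonds along the chain from an oxygen on an unsaturated carbon and a triple-bonded carbon, gives a 1.5-fold lower number from compound 3 to compound 4 (0.18 log units; within the scatter), so the shortest side chain in the set does not share the low reading of compound 2. In this assay, hydrogen in place of ethyl gives a 5.3-fold higher number from compound 2 to compound 4 (0.73 log units; beyond the scatter), while hydrogen in place of pentyl gives a 1.9-fold lower number from compound 1 to compound 4 (0.29 log units; within the scatter); side-chain length therefore does not order the series in one direction, and compound 2 stands apart from the other three, with compound 4 on the shorter side of it and compound 1 on the longer. No supporting data bear on what lies behind this reading.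

The compounds shown leave open whether the low reading belongs to a narrow range of chain lengths around that of compound 2 or to that one side chain alone. An ethyl or a butyl chain at this place would test the first reading, and a chain ending in an amine or a carboxylic acid would show whether the end of the chain matters here.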